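Swapping Phenoxy for Ethyl: An Expected Loss of Potency

The source may report more compounds than this note shows. Statements on the series, on what has been measured and on what is new or still open speak of the compounds shown alone.

Of the compounds shown here, three sharing one core have been measured in a functional assay on MCF7 cells (Homo sapiens) for antiproliferative activity, read by sulforhodamine B assay, with a stated time of 48 h; a lower number here means a stronger inhibitor, a higher number a weaker inhibitor. Compound 1 `O=C1NCCN1c1ccc(S(=O)(=O)Nc2ccc(OC(F)F)cc2)cc1` gives 760 nM and compound 2 `CCCCOc1ccc(NS(=O)(=O)c2ccc(N3CCNC3=O)cc2)cc1` gives 870 nM in that test. Compound 3 `O=C1NCCN1c1ccc(S(=O)(=O)Nc2cccc(Oc3ccccc3)c2)cc1` gives 220 nM and stands at the lowest of the three numbers; its gaps to compound 1 and to compound 2 both lie beyond the usual scatter, so compound 3 is the strongest inhibitor of the set. Compound 4 `CCc1cccc(NS(=O)(=O)c2ccc(N3CCNC3=O)cc2)c1` has not been measured yet. It differs from compound 3 in one place: ethyl in place of phenoxy on an aromatic carbon.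

Among the compounds with values here, the only measured step, a 1.1-fold higher number from compound 1 to compound 2 (0.06 log units; within the scatter), exchanges one group on an oxygen for another and leaves the number essentially unchanged; it does not remove the oxygen or a ring, so it bears only loosely on the present change. What the numbers do show is that compound 3, carrying phenoxy, sits well below compounds 1 and 2, which carry smaller groups on an oxygen. Removing the phenoxy is therefore expected to raise the number, a step estimated at a 3.2-fold higher number from compound 3 to compound 4 (0.50 log units; beyond the scatter) in size. Compound 4 is expected to give about 700 nM, with 250 nM as the lower end and 2000 nM as the upper end of the range.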

Compound 4, half-maximal inhibitory concentration: 130 nM
Beside the measured number, compound 4's estimate is 5.4-fold (0.73 log units) above it; the whole stated range lies above it.
By their numbers in this assay, from the lowest: compounds 4 and 3 (each within the scatter of the next); then compounds 1 and 2 (each within the scatter of the next).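

In this assay, replacing phenoxy with ethyl on this aromatic carbon gives a 1.7-fold lower number from compound 3 to compound 4 (0.23 log units; within the scatter), so the two compounds cannot be told apart. This pair separates the effect of this one group from the rest of the structure: the second aromatic ring and the oxygen of phenoxy can both be removed here without a change beyond the scatter, which shows that neither is required for a number in this range in this assay. Nothing available explains why the values of these two compounds stay so close.

The compounds shown do not tell whether the number would hold with a plain hydrogen, a methyl or a longer chain such as hexyl on this carbon. They also leave open how a charged group, such as an amine or a carboxylic acid, would fare there.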